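Aryl in place of ester: expected cytotoxicity of compound 4

The source may report more compounds than this note shows. Statements on the series, on what has been measured and on what is new or still open speak of the compounds shown alone.

Compound 3 `COC(=O)Cn1cc(CNC(=O)c2cnc(Nc3ccc(C#N)cc3)cc2Oc2c(C)cc(C)cc2C)nn1` is the reference point. In an ADME assay on MT4 cells (Homo sapiens) for cytotoxicity, read by MTT assay, with a stated time of 5 days (on this read-out lower numbers stand for higher toxicity in this test and higher numbers for lower toxicity in this test), compound 3 gives 13800 nM, the top of the two numbers available, though the gap to its neighbour is small. Compound 2 `CCOC(=O)Cn1cc(CNC(=O)c2cnc(Nc3ccc(C#N)cc3)cc2Oc2c(C)cc(C)cc2C)nn1` gives 9530 nM, and the pair differ by a 1.4-fold higher number from compound 2 to compound 3 (0.16 log units; within the scatter). Compound 1 `Cc1cc(C)c(Oc2cc(Nc3ccc(C#N)cc3)ncc2C(=O)NCc2cn(Cc3ccccc3[N+](=O)[O-])nn2)c(C)c1` gives only a limit, > 212000 nM. Its steps to the two esters are large: an at least 22-fold lower number from compound 1 to compound 2 (1.34 log units; beyond the scatter) and an at least 15-fold lower number from compound 1 to compound 3 (1.18 log units; beyond the scatter).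

Compound 4 `Cc1cc(C)c(Oc2cc(Nc3ccc(C#N)cc3)ncc2C(=O)NCc2cn(Cc3ccc(Cl)cc3)nn2)c(C)c1` differs from compound 3 by 4-chlorophenyl in place of methoxycarbonyl on a saturated chain carbon bound to an aromatic nitrogen. The step that bears on it runs the other way: the exchange that carried compound 1 to compound 3 replaced an aryl group with an ester and gave an at least 15-fold lower number from compound 1 to compound 3 (1.18 log units; beyond the scatter), so the return from an ester to an aryl group, here 4-chlorophenyl, is expected to raise the number again. Whether 4-chlorophenyl tracks 2-nitrophenyl exactly is not shown, so the expected rise is taken as large but uncertain. Compound 4 is therefore estimated at 100000 nM, between 30000 nM and 300000 nM. A step of a 7.2-fold higher number from compound 3 to compound 4 (0.86 log units; beyond the scatter) is expected in this assay. There is a fair chance that only a limit is returned, as compound 1 showed (the limit of > 212000 nM in this assay, at which 1 of the 3 values shown sits).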

Compound 4, half-maximal cytotoxic concentration: >= 120000 nM
Compound 4: a limit, no number; the forecaster's own chance of this, stated with the estimate: 45%; middle value at least 1.2-fold (0.07 log units) away from the limit.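

In this assay, compound 1 had tied a high number at this position to a single aryl group, 2-nitrophenyl, whereas compound 4 shows that an aryl group without a nitro substituent, 4-chlorophenyl, also separates clearly from both esters: an at least 8.6-fold higher number from compound 3 to compound 4 (0.93 log units; beyond the scatter) and an at least 12-fold higher number from compound 2 to compound 4 (1.10 log units; beyond the scatter). Compound 4 gives only a limit and no number, so these steps fix a minimum size for the change and not its full extent: the limit of >= 120000 nM in this assay, at which 1 of the 4 values shown sits. Compound 1 also gives only a limit, so the step from compound 1 to compound 4 cannot be read and the two aryl groups cannot be placed in order: the limit of > 212000 nM in this assay, at which 1 of the 4 values shown sits.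

The compounds shown leave open whether the high numbers follow from an aryl group as such or simply from the absence of an ester, a question that a plain propyl chain, an amine or a carboxylic acid on the same saturated chain carbon could help to settle. They also leave open what an unsubstituted phenyl would give at this position, and whether a methoxy or a fluoro substituent on that ring would keep the number as high.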